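A few compounds are considered here, and "the series" means these few. Any claim that something is new, unique, unknown or untested is made for them only; others in the source may bear on it.

Of the compounds shown here, three have been tested in an assay on isolated protein (Oryctolagus cuniculus) for binding affinity to Adrenergic receptor alpha-1 (Homo sapiens); a lower number here means a stronger inhibitor, a higher number a weaker inhibitor. Compound 1 `CN(C)CC1OCc2c1ccc(O)c2O` gives 1160 nM. Compound 2 `CNCC1OCc2c1ccc(O)c2O` differs from compound 1 in a single place: hydrogen in place of methyl on an amine nitrogen. In this assay compound 2 gives 1970 nM. That change made a 1.7-fold higher number from compound 1 to compound 2 (0.23 log units; within the scatter). Compound 3 `CN(C)CC1CCc2c1ccc(O)c2O` is built on a different core, and the difference between the two cores is not broken down here. In this assay compound 3 gives 6900 nM, the highest number of the three, beyond the scatter from both compound 1 and compound 2.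

Compound 4 `CNCC1CCc2c1ccc(O)c2O` stands to compound 3 as compound 2 stands to compound 1: hydrogen in place of methyl on an amine nitrogen. The surroundings of the amine nitrogen read the same in both pairs, so this is the same change, now made on the core of compound 3. The step from compound 3 to compound 4 in this assay is expected to be about a 1.6-fold higher number from compound 3 to compound 4 (0.20 log units; within the scatter), because the same change on the other core gave a 1.7-fold higher number from compound 1 to compound 2 (0.23 log units; within the scatter). Compound 4 is therefore expected to give roughly 11000 nM in this assay, most likely between 5500 nM and 22000 nM.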

Compound 4, inhibition constant: 2000 nM
The estimate for compound 4 lay 5.5-fold (0.74 log units) above the measured number; measured number outside the range, below it.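

Taking the methyl off the amine nitrogen does not carry over from one core to the other in this assay: the same change on two cores in this assay, a 1.7-fold higher number (0.23 log units; within the scatter) from compound 1 to compound 2 and a 3.5-fold lower number (0.54 log units; beyond the scatter) from compound 3 to compound 4, 5.9-fold (0.77 log units) apart, beyond the scatter of two such steps Here the change gives a 3.5-fold lower number from compound 3 to compound 4 (0.54 log units; beyond the scatter), so on this core the secondary amine is the stronger binder of the pair, while on the other core the same change leaves a step within the scatter. Within the data shown here, this shows that a step measured on one core could not be used as a forecast for the other, but with only two pairs it does not show which feature of the cores lies behind the gap, or how a third core would respond.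

The compounds shown leave open how an ethyl group or a longer chain on the amine nitrogen would behave on each core. They also leave open whether a primary amine, with both methyl groups replaced by hydrogen, would follow the core of compound 1 or the core of compound 3.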